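This account rests on a few compounds, and the source may have more. Where it says the series, first, only, none or still open, it means among the compounds named here.

Compound 3 `CC1=C(/C=C/C(=O)/C=C/c2ccc(C)cc2)C(C)(C)CCC1` stands second highest of the three numbers in a functional assay on Hep cells (Homo sapiens) for cytotoxicity, read by sulforhodamine B assay, with a stated time of 48 h (a lower number here means a stronger inhibitor, a higher number a weaker inhibitor), where compound 3 gives 44100 nM; compound 1 `CC1=C(/C=C/C(=O)/C=C/c2ccc(Br)cc2)C(C)(C)CCC1` gives 34500 nM and compound 2 `CC1=C(/C=C/C(=O)/C=C/c2ccc(F)cc2)C(C)(C)CCC1` gives 55800 nM. The change to compound 4 `CC1=C(/C=C/C(=O)/C=C/c2ccccc2Cl)C(C)(C)CCC1` is 2-chlorophenyl in place of 4-methylphenyl on a double-bonded chain carbon bound to a double-bonded chain carbon. The measured steps that bear on it all exchange the substituent on the aryl ring: a 1.3-fold higher number from compound 1 to compound 3 (0.11 log units; within the scatter), a 1.3-fold lower number from compound 2 to compound 3 (0.10 log units; within the scatter) and a 1.6-fold higher number from compound 1 to compound 2 (0.21 log units; within the scatter), each within the scatter. Compound 4 differs in a different way, since the whole 2-chlorophenyl replaces the 4-methylphenyl, yet nothing in the data points to a step beyond the scatter. Compound 4 is therefore expected to give about 42000 nM in this assay, within 20000 nM to 90000 nM, which means an expected step of a 1.1-fold lower number from compound 3 to compound 4 (0.02 log units; within the scatter).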

Compound 4, half-maximal inhibitory concentration: 54200 nM
Beside the measured number, compound 4's estimate is 1.3-fold (0.11 log units) below it; the range from low to high includes it.
By their numbers in this assay, from the lowest: compounds 1, 3, 4 and 2 (each within the scatter of the next).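

In this assay, 2-chlorophenyl in place of 4-methylphenyl gives a 1.2-fold higher number from compound 3 to compound 4 (0.09 log units; within the scatter), and the other two comparisons give a 1.0-fold lower number from compound 2 to compound 4 (0.01 log units; within the scatter) and a 1.6-fold higher number from compound 1 to compound 4 (0.20 log units; within the scatter). At this position, then, 2-chlorophenyl falls within the scatter of 4-methylphenyl, 4-fluorophenyl and 4-bromophenyl, so the result extends the flat picture beyond those three groups. No evidence is available to explain this result. On these data alone, whether an amine, a carboxylic acid or a longer chain on the aryl ring would take the number beyond the scatter remains open.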